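Swapping the amide-bound aryl group while cytotoxicity stays flat

This account rests on a few compounds, and the source may have more. Where it says the series, first, only, none or still open, it means among the compounds named here.

Measured compounds:
compound 1, `O=C(Nc1ccc(Cl)cn1)C1CCCN(C(=O)c2cc(C(F)(F)F)cc(C(F)(F)F)c2)C1`, 0%
compound 2, `O=C(Nc1ccc(Cl)cc1)C1CCCN(C(=O)c2cccc(-c3ccco3)c2)C1`, 0%
compound 3, `O=C(Nc1ccc(Cl)cc1)C1CCCN(C(=O)c2cccc(-c3cccs3)c2)C1`, 4%

All three compounds were tested in an ADME assay on PC-3 cells (Homo sapiens) for cytotoxicity, read by WST assay, tested at 100 uM; on this read-out higher numbers stand for more inhibition at the one concentration tested (going by the name of the read-out) and lower numbers for less inhibition. Compound 1 gives 0% in this assay, level with compound 2 at the digits shown, and together these are the lowest of the three numbers. Compound 3 lies closest above, with a step of a number 4 percentage points higher from compound 2 to compound 3 (within the scatter), which falls within the scatter. So none of the measured compounds shows appreciable cytotoxicity at the tested concentration.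

The unmeasured compound 4, `O=C(Nc1cccc(CN2CCCC2)c1)C1CCCN(C(=O)c2cc(C(F)(F)F)cc(C(F)(F)F)c2)C1`, differs from compound 1 in one place: 3-((pyrrolidin-1-yl)methyl)phenyl in place of 5-chloropyridin-2-yl on an amide-type nitrogen.

For the measured compounds named here, no measured step alters the group on the amide-type nitrogen; the only measured step, from compound 2 to compound 3, alters a group on an aromatic carbon elsewhere and stays within the scatter. With every measured number near zero, a step of a number 5 percentage points higher from compound 1 to compound 4 (within the scatter) is expected, that is none beyond the scatter. Compound 4 is therefore estimated at 5%, with a range from 0% to 25%.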

Compound 4, a percentage reported as inhibition, at one concentration (the size of the read-out at that concentration, not a potency): 51%
The estimate for compound 4 lay 46 percentage points below the measured number; measured number above the stated range.
By their numbers in this assay, from the lowest: compounds 1, 2 and 3 (each within the scatter of the next); then compound 4.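

In this assay, for the compounds shown here, the group on the amide-type nitrogen proves able to shift the read-out: 3-((pyrrolidin-1-yl)methyl)phenyl in place of 5-chloropyridin-2-yl brings a number 51 percentage points higher from compound 1 to compound 4 (beyond the scatter), the only step in this set beyond the scatter. Going by these compounds alone, until now all the numbers sat near zero, and no measured step had touched this position. No supporting data are available to explain the rise.

The change replaces one aromatic ring with another and also adds a pyrrolidine ring, so this single step cannot show which part matters. A plain phenyl, a dimethylaminomethyl group or a morpholinylmethyl group on the same ring would help separate these parts, and placing 3-((pyrrolidin-1-yl)methyl)phenyl on the core of compound 2 would test whether the rise carries over.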